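Fluorine addition on a sulfoxide analogue: expected binding shift

The source may hold more compounds than are shown below. What is called first, only, known or untested is meant among the compounds shown, and "the series" means these compounds.

Compounds measured so far:
compound 1, `O=C(c1ccccc1F)N1CCC(NCCSC(c2ccc(F)cc2)c2ccc(F)cc2)CC1`, 3.57 nM
compound 2, `O=C(c1ccc(F)cc1F)N1CCC(NCCSC(c2ccc(F)cc2)c2ccc(F)cc2)CC1`, 20.6 nM
compound 3, `O=C(c1ccccc1F)N1CCC(NCC[S+]([O-])C(c2ccc(F)cc2)c2ccc(F)cc2)CC1`, 1310 nM

In an assay on membranes from Cortex for displacement of a labelled ligand from Sigma non-opioid intracellular receptor 1 (Cavia porcellus), read by scintillation counting, with a stated time of 120 min (a lower number here means a stronger inhibitor, a higher number a weaker inhibitor), compound 1 gives 3.57 nM. Compound 2 carries the change (fluoro in place of hydrogen on an aromatic carbon), and this gave a 5.8-fold higher number from compound 1 to compound 2 (0.76 log units; beyond the scatter). Compound 3 has the highest number of the three measured, at 1310 nM; how its core differs from that of compound 1 is not broken down here.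

Compound 4, `O=C(c1ccc(F)cc1F)N1CCC(NCC[S+]([O-])C(c2ccc(F)cc2)c2ccc(F)cc2)CC1`, is not yet measured. It stands to compound 3 as compound 2 stands to compound 1: the change (fluoro in place of hydrogen on an aromatic carbon), the same change as before. Because the earlier change gave a 5.8-fold higher number from compound 1 to compound 2 (0.76 log units; beyond the scatter), the same weakening is expected here, estimated as a 5.7-fold higher number from compound 3 to compound 4 (0.76 log units; beyond the scatter). Compound 4 is therefore expected to give about 7500 nM in this assay, most likely between 2500 nM and 25000 nM.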

Compound 4, inhibition constant: 171 nM
The estimate for compound 4 lay 44-fold (1.64 log units) above the measured number; the measured number lies below the stated range.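

In this assay, the change from 2-fluorophenyl to 2,4-difluorophenyl gave a 7.7-fold lower number from compound 3 to compound 4 (0.88 log units; beyond the scatter), opposite in direction to the earlier step. The same change therefore did not carry over from one core to the other, and its effect in this series depends on the core that bears it: the same change on two cores in this assay, a 5.8-fold higher number (0.76 log units; beyond the scatter) from compound 1 to compound 2 and a 7.7-fold lower number (0.88 log units; beyond the scatter) from compound 3 to compound 4, 44-fold (1.65 log units) apart, beyond the scatter of two such steps

This rests on a single pair for each core, so it gives no rule for other cores and does not show why the two steps part.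

The compounds shown leave open whether a chloro or methoxy group in the same place would split between the two cores in the same way. They also leave open how the change would behave on a sulfone.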